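Working notes: cytotoxicity step from compound 2 to compound 3

The source may hold more compounds than are shown below. What is called first, only, known or untested is meant among the compounds shown, and "the series" means these compounds.

Measured so far in an ADME assay on MT4 cells (Homo sapiens) for cytotoxicity, read by MTT assay; on this read-out lower numbers stand for higher toxicity in this test and higher numbers for lower toxicity in this test:
- compound 1 `O=C(CSc1nnnn1-c1cccc2ccccc12)N/N=C/c1ccc(F)cc1`: > 307000 nM, a limit of the assay and not a number
- compound 2 `COc1cccc(/C=N/NC(=O)CSc2nnnn2-c2cccc3ccccc23)c1OC`: 192000 nM

Going by the values given here, compound 2, at 192000 nM, holds the only exact number so far. Compound 3 `O=C(CSc1nnnn1-c1cccc2ccccc12)N/N=C/c1ccccc1O` carries 2-hydroxyphenyl in place of 2,3-dimethoxyphenyl on a carbon with a double bond to nitrogen. Among the compounds with values here, the only measured step at that place is an at least 1.5-fold lower number from compound 1 to compound 2 (0.20 log units; that floor lies within the scatter), with 2,3-dimethoxyphenyl in place of 4-fluorophenyl. That single step gives only a floor for its size, so no change beyond the scatter is expected in this assay. The expected step is a 1.5-fold lower number from compound 2 to compound 3 (0.17 log units; within the scatter), which stays within the scatter. For compound 3 the estimate is 130000 nM, with an expected range of 40000 nM to 320000 nM.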

Compound 3, half-maximal cytotoxic concentration: 4850 nM
Compound 3: middle estimate off by 27-fold (1.43 log units), on the high side; the measured number lies below the stated range.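

In this assay, the group on a carbon with a double bond to nitrogen can shift the number well beyond the scatter: 2-hydroxyphenyl in place of 2,3-dimethoxyphenyl gives a 40-fold lower number from compound 2 to compound 3 (1.60 log units; beyond the scatter), whereas the earlier step at this place did not pass the scatter. 2-hydroxyphenyl in place of 4-fluorophenyl gives an at least 63-fold lower number from compound 1 to compound 3 (1.80 log units; beyond the scatter), so compound 3 has the lower number against both neighbours. Compound 1 carries a limit and not a number, so that second step is only a floor: the limit of > 307000 nM in this assay, at which 1 of the 3 values shown sits.

From the compounds shown here alone, it stays open whether the lower number goes with the hydroxy group itself or with the loss of the two methoxy groups. A 2-methoxyphenyl or a 2-aminophenyl group at this place would help separate these two readings.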